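The compounds below may be only part of what the source reports. "The series", "measured", "known", "first", "only" and "open" are said of these compounds alone.

Measured compounds in a functional assay on ECa-109 cells (Homo sapiens) for antiproliferative activity, read by MTT assay, with a stated time of 48 h; a higher number here means a weaker inhibitor, a lower number a stronger inhibitor:
compound 1 `CN(C)CCCn1nc(C2=C(c3cn(C)c4ccccc34)C(=O)NC2=O)c2cccnc21` — > 100000 nM
compound 2 `Cn1cc(C2=C(c3nn(CCCn4cccc4)c4ncccc34)C(=O)N(c3ccccc3)C2=O)c2ccccc21` — > 100000 nM
compound 3 `Cn1cc(C2=C(c3nn(CCCN4CCCCC4)c4ncccc34)C(=O)N(c3ccc(Cl)cc3)C2=O)c2ccccc21` — > 100000 nM

Each of these three values is a limit of the assay and not a number. In this assay compound 1 gives > 100000 nM, a limit. Compound 2 gives > 100000 nM, a limit as well. Compound 3 gives > 100000 nM, again a limit. Among the measured compounds shown here, compound 2 therefore stands where every measured compound stands, at the limit of > 100000 nM in this assay, at which 3 of the 3 values shown sit, and no step between measured compounds can be sized or given a direction.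

Compound 4 `CN(C)CCCn1nc(C2=C(c3cn(C)c4ccccc34)C(=O)N(c3ccccc3)C2=O)c2cccnc21` differs from compound 2 in one place: dimethylamino in place of 1H-pyrrol-1-yl on a saturated chain carbon, three bonds along the chain from an aromatic nitrogen. Compound 1 carries this dimethylamino chain already; in this assay compound 1 gives > 100000 nM, a limit. With all three measured compounds at the limit of > 100000 nM in this assay, at which 3 of the 3 values shown sit, the step that the limit leaves unreadable from compound 2 to compound 4 is expected to be none beyond the scatter. Compound 4 is expected to give 150000 nM, with a range from 30000 nM to 1000000 nM, and most likely to be reported as a limit again.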

Compound 4, half-maximal inhibitory concentration: 5840 nM
The estimate for compound 4 lay 26-fold (1.41 log units) above the measured number, outside the stated range (below it).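

In this assay, the result shows that the end of the chain is a place that responds: dimethylamino in place of 1H-pyrrol-1-yl gives an at least 17-fold lower number from compound 2 to compound 4 (1.23 log units; beyond the scatter). The phenyl on the amide-type nitrogen in a ring matters as well, with phenyl in place of hydrogen giving an at least 17-fold lower number from compound 1 to compound 4 (1.23 log units; beyond the scatter), so among these compounds the 3-(dimethylamino)propyl chain and the phenyl give a measurable number only when they occur together, as compound 1 and compound 2 each carry just one of them. Compound 4 is the only compound shown with a number and not a limit of the assay: the limit of > 100000 nM in this assay, at which 3 of the 4 values shown sit.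

Both steps start from a limit, so their full size cannot be read. The compounds shown leave open whether a diethylamino or morpholin-4-yl group, or a longer chain, would keep this gain, and whether a methoxy group on the phenyl would alter it.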